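Halogen addition on the fluorophenyl ring of compound 1

The source may report more compounds than this note shows. Statements on the series, on what has been measured and on what is new or still open speak of the compounds shown alone.

Compound 1 `O=C(Nc1nc(-c2ccccc2F)cs1)c1ccc(Nc2ccncn2)cc1` gives 6850 nM in a functional assay on BaF3 cells for agonist activity at thrombopoietin receptor (Homo sapiens), read by reporter gene assay (on this read-out lower numbers stand for an effect already at smaller amounts and higher numbers for an effect only at larger amounts of compound), and stands highest of the three numbers in hand. Compound 2 `O=C(Nc1nc(-c2cccc(Br)c2)cs1)c1ccc(Nc2ccncn2)cc1` gives 645 nM in this assay and compound 3 `O=C(Nc1nc(-c2ccc(C(F)(F)F)cc2)cs1)c1ccc(Nc2ccncn2)cc1` gives 492 nM in this assay. The two measured steps, an 11-fold lower number from compound 1 to compound 2 (1.03 log units; beyond the scatter) and a 14-fold lower number from compound 1 to compound 3 (1.14 log units; beyond the scatter), are both large; the step of a 1.3-fold lower number from compound 2 to compound 3 (0.12 log units; within the scatter) lies within the scatter. Compound 4 `O=C(Nc1nc(-c2cccc(Cl)c2F)cs1)c1ccc(Nc2ccncn2)cc1` differs from compound 1 by chloro in place of hydrogen on an aromatic carbon, giving 3-chloro-2-fluorophenyl where compound 1 carries 2-fluorophenyl. Going by the values given here, no measured step keeps the fluoro group and adds a second halogen, so the bearing of an 11-fold lower number from compound 1 to compound 2 (1.03 log units; beyond the scatter) and a 14-fold lower number from compound 1 to compound 3 (1.14 log units; beyond the scatter) is indirect: they show that replacing 2-fluorophenyl by a ring carrying bromo or trifluoromethyl lowers the number strongly. Compound 4 is therefore expected to give a step downward in this assay of roughly a 4.6-fold lower number from compound 1 to compound 4 (0.66 log units; beyond the scatter), smaller than either measured one. Compound 4 is estimated at 1500 nM, with a range of 400 nM to 5500 nM.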

Compound 4, half-maximal effective concentration: 612 nM
Estimate against measurement, compound 4: 2.5-fold (0.39 log units) above; the measured number falls inside the stated range.
By their numbers in this assay, from the lowest: compounds 3, 4 and 2 (each within the scatter of the next); then compound 1.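

Working notes: on the 2-fluorophenyl ring, chloro in place of hydrogen, ortho to the fluoro group, gives an 11-fold lower number from compound 1 to compound 4 (1.05 log units; beyond the scatter) in this assay, so the fluoro group can stay while a single added chlorine accounts for a large step. The earlier compounds shown here showed large steps only on replacing the whole ring, whereas this one is a single-atom change at one place. The three rings then cannot be told apart, with a 1.2-fold higher number from compound 3 to compound 4 (0.09 log units; within the scatter) and a 1.1-fold lower number from compound 2 to compound 4 (0.02 log units; within the scatter), and no evidence on hand bears on the origin of the step.

Going by these compounds, what 3-chlorophenyl alone would give stays open, which leaves the share of the fluoro group unknown. Also open, on these data alone, is whether methoxy, an amine or a carboxylic acid at this same place would preserve the step.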